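The source may report more compounds than this note shows. Statements on the series, on what has been measured and on what is new or still open speak of the compounds shown alone.

Working notes on the series

Within the data shown here, compound 2 `Cc1cccc(NC(=O)CN2CCC(c3nccs3)CC2)c1` gives 1 nM in a functional assay on HEK293 cells for agonist activity at D(4) dopamine receptor (Homo sapiens), read by FLIPR (on this read-out higher numbers stand for an effect only at larger amounts of compound and lower numbers for an effect already at smaller amounts), the lowest of the three numbers measured so far. Compound 1 `O=C(CN1CCC(c2cccc[n+]2[O-])CC1)Nc1cccc(Cl)c1` gives 62 nM in this assay, and compound 3 `O=C(CN1CCC(c2cccc[n+]2[O-])CC1)Nc1ccc(F)cc1F` gives 103 nM. Among the measured compounds shown here, the one step measured within one change, a 1.7-fold higher number from compound 1 to compound 3 (0.22 log units; within the scatter), concerns the anilide part only.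

The step to compound 4 `Cc1cccc(NC(=O)CN2CCC(c3ccc(O)cn3)CC2)c1` is a different kind of change: 5-hydroxypyridin-2-yl in place of 1,3-thiazol-2-yl on a saturated ring carbon. No measured pair differs solely at this saturated ring carbon, so no listed step bears directly on it. Compounds 1 and 3 carry another six-membered aromatic group at that same position, but they also differ from compound 2 in the anilide. Compound 1 gives 62 nM and compound 3 gives 103 nM, and neither value can be split into the two contributions. For the measured compounds named here, what they do show is that the only compounds lacking the thiazolyl group sit well above compound 2.

Going by the values given here, with that as the sole guide, the expectation is a step of a 6.0-fold higher number from compound 2 to compound 4 (0.78 log units; beyond the scatter) in this assay, toward a higher number, with wide uncertainty. Compound 4 is therefore estimated at 6 nM, with a range from 1.5 nM to 30 nM.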

Compound 4, half-maximal effective concentration: 3.8 nM
The estimate for compound 4 lay 1.6-fold (0.20 log units) above the measured number; low and high end bracket the measured number.
By their numbers in this assay, from the lowest: compound 2; then compound 4; then compounds 1 and 3 (each within the scatter of the next).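

Among these compounds, with the anilide held constant, this assay gives a 3.8-fold higher number from compound 2 to compound 4 (0.58 log units; beyond the scatter) for 5-hydroxypyridin-2-yl in place of 1,3-thiazol-2-yl, the first reading of this saturated ring carbon on its own, which compounds 1 and 3 could not provide since they also differ in the anilide. The position therefore takes a six-membered aromatic ring bearing a hydroxyl in place of the five-membered aromatic ring at a modest cost, and compound 4 at 3.8 nM stays in the low nanomolar range on this read-out. No measurement at hand accounts for the step, so the parts played by ring size, the hydroxyl and the ring hetero atoms stay unassigned.

The compounds shown leave open how much of the step belongs to the hydroxyl and how much to the change of ring; plain pyridin-2-yl or 5-methoxypyridin-2-yl on the same core would separate the two. Also open, on these data alone, is whether the step carries over to another anilide, such as the 3-chlorophenyl amide of compound 1.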